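Swapping Thiophen-3-yl for Furan-2-yl on a Shared Core

The compounds below may be only part of what the source reports. "The series", "measured", "known", "first", "only" and "open" are said of these compounds alone.

Three compounds built on a shared core, each carrying a small aromatic group, have been tested in a functional assay on K562 cells (Homo sapiens), read by MTT assay, with a stated time of 72 h; a lower number here means a stronger inhibitor, a higher number a weaker inhibitor. Compound 1 `Nc1nc(N)c2c(-c3cc4ccccc4o3)cn([C@@H]3O[C@H](CO)[C@@H](O)[C@H]3O)c2n1` gives 18600 nM in this assay, a weak inhibitor. Compound 2 `Nc1nc(N)c2c(-c3ccoc3)cn([C@@H]3O[C@H](CO)[C@@H](O)[C@H]3O)c2n1` gives only a limit of this assay, > 20000 nM. The step of an at least 1.0-fold higher number from compound 1 to compound 2 (0.03 log units; that floor lies within the scatter) thus shows that exchanging one such aromatic group for another did not move the number out of the scatter, and both compounds stay weak.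

Compound 3 `O=c1[nH]cnc2c1c(-c1ccsc1)cn2[C@@H]1O[C@H](CO)[C@@H](O)[C@H]1O` also gives only a limit of this assay, > 20000 nM. Where compound 3 stands is therefore known only as a limit, not as a number, and it shares this with one other compound, as shown by the limit of > 20000 nM in this assay, at which 2 of the 3 values shown sit.

Compound 4 `O=c1[nH]cnc2c1c(-c1ccco1)cn2[C@@H]1O[C@H](CO)[C@@H](O)[C@H]1O` has not yet been measured. It differs from compound 3 by furan-2-yl in place of thiophen-3-yl on an aromatic carbon. Among the measured compounds shown here, the only measured step that bears on this kind of exchange is an at least 1.0-fold higher number from compound 1 to compound 2 (0.03 log units; that floor lies within the scatter), which stayed within the scatter. On that basis, compound 4 is expected to show no step beyond the scatter, a step that the limit leaves unreadable from compound 3 to compound 4. Compound 4 is therefore estimated at 30000 nM, with a range from 15000 nM to 100000 nM, and most likely this assay will again report only a limit.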

Compound 4, half-maximal inhibitory concentration: 15500 nM
Compound 4: middle estimate off by 1.9-fold (0.29 log units), on the high side; the measured number falls inside the stated range.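

In this assay, among the compounds shown here, compound 4 gives 15500 nM, the first actual number for the core shared by compound 3 and compound 4, so this position on that core can carry a group that keeps the reading inside the range of the assay. Thiophen-3-yl and furan-2-yl are both five-membered aromatic rings of the same heavy-atom count, one holding sulfur and the other oxygen, and exchanging them gives an at least 1.2-fold lower number from compound 3 to compound 4 (0.11 log units; that floor lies within the scatter), a floor that does not separate the two compounds, although the true step could be larger. That step can be read only as a floor because the value for compound 3 is a limit and not a number: the limit of > 20000 nM in this assay, at which 2 of the 4 values shown sit.

Going by these compounds, how far compound 3 really lies from compound 4 stays unknown, and so does whether the change in the ring atom or the change in the point of attachment matters more, since the two change together here. Also open, on these data alone, is how this position on the same core would respond to a phenyl ring, an amine or a carboxylic acid on that aromatic carbon, or to a longer chain.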